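Compound 3 to compound 4: chloro for trifluoromethoxy

The source may hold more compounds than are shown below. What is called first, only, known or untested is meant among the compounds shown, and "the series" means these compounds.

Compound 3 `Cc1cc(NC(=O)Nc2cccc(OC(F)(F)F)c2)c2ccccc2n1` anchors this step. For the measured compounds named here, in an ADME assay on Raji cells (Homo sapiens) for cytotoxicity, with a stated time of 72 h (a lower number here means that less compound is needed, a higher number that more compound is needed for the effect), compound 3 gives 9000 nM, the only true number in the set. Compound 1 `Cc1cc(NC(=O)Nc2cccc([N+](=O)[O-])c2)c2ccccc2n1` reads > 25000 nM, which is a limit of the assay. Compound 2 `Cc1cc(NC(=O)Nc2ccc(O)cc2)c2ccccc2n1` reads > 25000 nM, which is also a limit of the assay. The evidence is therefore thin, with the limit of > 25000 nM in this assay, at which 2 of the 3 values shown sit.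

Compound 4 `Cc1cc(NC(=O)Nc2cccc(Cl)c2)c2ccccc2n1` has chloro in place of trifluoromethoxy on an aromatic carbon, meta to a large group: chloro in place of trifluoromethoxy on an aromatic carbon.

One measured step involves the same place on the ring: an at least 2.7-fold lower number from compound 1 to compound 3 (0.44 log units; beyond the scatter). Going by these compounds, it is beyond the scatter, but it starts from a limit, so its full size is unknown. It shows that a change at this place can move the number in this assay, but it does not involve chloro and gives no direction for the new exchange. No step beyond the scatter is therefore expected, with a slight lean towards a higher number, and a reading at the limit remains possible. The expected change is a 1.3-fold higher number from compound 3 to compound 4 (0.12 log units; within the scatter), which would lie within the usual scatter. For compound 4 the estimated value is 12000 nM, with an expected range of 4000 nM to 25000 nM.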

Compound 4, half-maximal effective concentration: 18000 nM
Compound 4: middle estimate off by 1.5-fold (0.18 log units), on the low side; measured number inside the range.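

In this assay, for the compounds shown here, chloro in place of trifluoromethoxy gives a 2.0-fold higher number from compound 3 to compound 4 (0.30 log units; within the scatter), the first step at this place with a true number at both ends, so these two groups are not told apart here even though 5 heavy atoms give way to 1. Chloro in place of nitro gives an at least 1.3-fold lower number from compound 1 to compound 4 (0.14 log units; that floor lies within the scatter), and 3-chlorophenyl in place of 4-hydroxyphenyl gives an at least 1.3-fold lower number from compound 2 to compound 4 (0.14 log units; that floor lies within the scatter); both floors lie within the scatter, so neither step alone separates compound 4 from the compound it starts from. Compound 3 and compound 4 now both give true numbers, while the real size of the two steps from the other compounds stays unknown: the limit of > 25000 nM in this assay, at which 2 of the 4 values shown sit.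

The compounds shown leave open how an amine, a carboxylic acid or a methoxy group at this place would read against chloro and trifluoromethoxy. They also leave open whether chloro and trifluoromethoxy would stay this close on another carbon of the ring, or on a shared core changed elsewhere.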